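The source may report more compounds than this note shows. Statements on the series, on what has been measured and on what is new or still open speak of the compounds shown alone.

The compounds here share a hydrazone built from an isonicotinoyl amide, and they were examined for how much of each a cell culture tolerates before harm appears. Compound 1 `O=C(N/N=C/c1c[nH]c2ccccc12)c1ccncc1` carries an indole ring on the hydrazone carbon. In an ADME assay on Vero cells (Chlorocebus sabaeus) for cytotoxicity (a higher number here means that more compound is tolerated, a lower number that less compound is tolerated), compound 1 reaches only the limit of the assay, reported as > 100 ug/mL, so no exact number is known for it. Compound 2 `COc1cccc(OC)c1/C=N/NC(=O)c1ccncc1` instead carries a dimethoxyphenyl ring on that carbon. In this assay, among the measured compounds shown here, compound 2 gives 100 ug/mL, which is the only exact number measured so far. The other result, that of compound 1, is a limit, as the line the limit of > 100 ug/mL in this assay, at which 1 of the 2 values shown sits, records.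

Compound 3 `COc1cccc(OC)c1/C=N/N(C(=O)c1ccccc1)C(=O)c1ccncc1` is compound 2 with one change: benzoyl in place of hydrogen on an amide-type nitrogen. For the measured compounds named here, since no step between two measured compounds has been recorded, no direction can be read from the data for this change. The step of a 1.3-fold lower number from compound 2 to compound 3 (0.10 log units; within the scatter) is therefore expected to stay within the usual scatter, with at most a small shift downward. Compound 3 is estimated to give 80 ug/mL in this assay, with a range from 30 ug/mL to 160 ug/mL.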

Compound 3, minimum cytotoxic concentration: 100 ug/mL
The estimate for compound 3 lay 1.3-fold (0.10 log units) below the measured number; the range from low to high includes it.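

Among the compounds shown here, the position in question is the amide-type nitrogen whose other neighbours are the carbonyl carbon and the double-bonded nitrogen, and the earlier compounds offered no step at all for a change there. In this assay the first such step shows no change at the digits printed from compound 2 to compound 3 (within the scatter), even though benzoyl is a large group to put in place of a hydrogen atom, so on this core the nitrogen can carry a six-membered aromatic ring of carbon without a visible shift in the amount of compound tolerated. This flat step comes with one caution, since the scale of the read-out has an upper end and one result is a limit of the assay: the limit of > 100 ug/mL in this assay, at which 1 of the 3 values shown sits.

For the compounds shown here, with only one step at this nitrogen, it remains open whether a small acetyl group, a longer alkyl chain, or a chain ending in an amine or a carboxylic acid would read the same way there. On these data alone, it also remains open whether benzoyl on this nitrogen would give a similar result with the indole ring of compound 1 in place of the dimethoxyphenyl ring.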